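Acyl group variation on a shared core: compound 4 expected

The source may hold more compounds than are shown below. What is called first, only, known or untested is meant among the compounds shown, and "the series" means these compounds.

Measured compounds:
compound 1 `CCC(=O)N(C)c1ccc2[nH]c(-c3n[nH]c4ccccc34)cc2n1` — in a functional assay on A549 cells (Homo sapiens) for antiproliferative activity, read by MTT assay, with a stated time of 72 h (a lower number here means a stronger inhibitor, a higher number a weaker inhibitor), compound 1 gives 15700 nM
compound 2 `CN(C(=O)C(C)(C)C)c1ccc2[nH]c(-c3n[nH]c4ccccc34)cc2n1` — in this assay compound 2 gives 24400 nM
compound 3 `CN(C(=O)c1ccccc1)c1ccc2[nH]c(-c3n[nH]c4ccccc34)cc2n1` — in this assay compound 3 gives 13800 nM

Compound 3 holds the lowest of the three numbers, but none of the others is separated from it by more than the scatter: the step of a 1.1-fold lower number from compound 1 to compound 3 (0.06 log units; within the scatter) and the step of a 1.8-fold lower number from compound 2 to compound 3 (0.25 log units; within the scatter) both stay inside it, as does a 1.6-fold higher number from compound 1 to compound 2 (0.19 log units; within the scatter). The three compounds share one core and differ only in the group on the carbonyl carbon next to the amide-type nitrogen.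

Compound 4 `CN(C(=O)CCc1ccccc1)c1ccc2[nH]c(-c3n[nH]c4ccccc34)cc2n1` continues this series with phenethyl in place of phenyl on a carbonyl carbon. All three measured steps bear on it, since each swaps one group on that same carbonyl carbon, and each was within the scatter. On that basis the step of a 1.1-fold higher number from compound 3 to compound 4 (0.04 log units; within the scatter) is expected to be small, with no clear direction beyond the scatter. Compound 4 is therefore estimated to give 15000 nM in this assay, within a range from 7000 nM to 32000 nM.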

Compound 4, half-maximal inhibitory concentration: 18100 nM
Beside the measured number, compound 4's estimate is 1.2-fold (0.08 log units) below it; the measured number falls inside the stated range.
By their numbers in this assay, from the lowest: compounds 3, 1, 4 and 2 (each within the scatter of the next).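

In this assay, phenethyl in place of phenyl on the carbonyl carbon gives a 1.3-fold higher number from compound 3 to compound 4 (0.12 log units; within the scatter) and phenethyl in place of tert-butyl gives a 1.3-fold lower number from compound 2 to compound 4 (0.13 log units; within the scatter) so a two-carbon chain carrying the ring leaves the number within the scatter of both earlier groups. Phenyl in place of hydrogen on the saturated chain, two bonds along from the carbonyl carbon, gives a 1.2-fold higher number from compound 1 to compound 4 (0.06 log units; within the scatter) and this step also stays within the scatter. All four groups on this carbonyl carbon thus give numbers within the scatter of one another, and nothing available explains this result.

As far as these compounds go, whether an amine or a carboxylic acid on this chain would carry the number beyond the scatter remains open. So does the outcome for a longer chain between the carbonyl carbon and the phenyl ring.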